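The source may hold more compounds than are shown below. What is called first, only, known or untested is meant among the compounds shown, and "the series" means these compounds.

Compound 1 `COC(=O)c1ccc(C(=O)Nc2cccc3c2N(S(=O)(=O)c2ccc(OC)cc2)CC3)cc1` is the weakest of the three compounds measured in a functional assay on MKN-45 cells (Homo sapiens) for cytotoxicity; a lower number here means a stronger inhibitor, a higher number a weaker inhibitor: compound 1 gives 312 nM, while compound 2 `COc1ccc(S(=O)(=O)N2CCc3cccc(NC(=O)c4ccc(F)cc4)c32)cc1` gives 45 nM and compound 3 `COc1ccc(S(=O)(=O)N2CCc3cccc(NC(=O)c4ccncc4)c32)cc1` gives 8.8 nM. The change to compound 4 `COc1ccc(C(=O)Nc2cccc3c2N(S(=O)(=O)c2ccc(OC)cc2)CC3)cc1` is methoxy in place of methoxycarbonyl on an aromatic carbon, so that the amide carbonyl carries 4-methoxyphenyl rather than 4-(methoxycarbonyl)phenyl. The measured steps that bear on this all leave compound 1 as the starting point. Removing the methoxycarbonyl in favour of fluoro gave a 6.9-fold lower number from compound 1 to compound 2 (0.84 log units; beyond the scatter), and exchanging the whole aryl group for pyridin-4-yl gave a 35-fold lower number from compound 1 to compound 3 (1.55 log units; beyond the scatter); the comparison a 5.1-fold lower number from compound 2 to compound 3 (0.71 log units; beyond the scatter) shows that the second of these owes part of its size to the pyridine itself. Among the measured compounds shown here, no measured step puts a methoxy at this position, so the direction is taken from the fluoro case and the size is kept smaller. Compound 4 is therefore expected to give a lower number, a 2.8-fold lower number from compound 1 to compound 4 (0.45 log units; beyond the scatter), and its estimated value is 110 nM within a range of 35 nM to 350 nM.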

Compound 4, half-maximal inhibitory concentration: 1600 nM
Compound 4: the middle estimate sits 15-fold (1.16 log units) below what was measured, and the stated range ends below it.
By their numbers in this assay, from the lowest: compound 3; then compound 2; then compound 1; then compound 4.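

Removing the methoxycarbonyl does not by itself lower the number in this assay: with methoxy at the same place, the change runs the other way (a 5.1-fold higher number from compound 1 to compound 4 (0.71 log units; beyond the scatter)), so the direction depends on the group that enters. Exchanging fluoro for methoxy alone gives a larger step (a 36-fold higher number from compound 2 to compound 4 (1.55 log units; beyond the scatter)), and replacing pyridin-4-yl with 4-methoxyphenyl gives a larger one still (a 180-fold higher number from compound 3 to compound 4 (2.26 log units; beyond the scatter)), which makes compound 4 the weakest of the four and shows how widely the number moves with this one part of the structure. Nothing shown here accounts for these differences.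

The compounds shown leave open whether an amine or a carboxylic acid at this place on the ring would side with fluoro or with methoxy. They also leave open whether a longer chain such as ethoxy would raise the number further.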